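The source may report more compounds than this note shows. Statements on the series, on what has been measured and on what is new or still open speak of the compounds shown alone.

Of the compounds shown here, three built on a shared core have been tested in an assay on isolated protein for inhibition of retinal dehydrogenase 2 (Homo sapiens); on this read-out higher numbers stand for weaker inhibition and lower numbers for stronger inhibition. Compound 1 `CC(Sc1nc2c(cnn2C)c(=O)n1-c1ccc(CCO)cc1)c1ccccc1` gives 216 nM. Compound 2 `Cn1ncc2c(=O)n(-c3ccccc3)c(SC(C)(C)c3ccccc3)nc21` gives 2200 nM, the highest of the three numbers, and compound 3 `CC(Sc1nc2nn(CC3COC3)cc2c(=O)n1-c1ccccc1)c1ccccc1` gives 80 nM, the lowest. Compound 1 thus stands second highest, closer to compound 3 than to compound 2, and both gaps lie beyond the usual scatter. Compound 4 `CC(Sc1nc2c(cnn2C)c(=O)n1-c1ccc(CO)cc1)c1ccccc1` has not yet been measured in this assay. It differs from compound 1 in one place: hydroxy in place of hydroxymethyl on a saturated chain carbon bound to an aromatic carbon. Among the measured compounds shown here, no measured pair shows this same change, so its effect is unknown from these data. The step expected is a 1.2-fold higher number from compound 1 to compound 4 (0.06 log units; within the scatter), small and without a clear direction. For compound 4 the estimate is 250 nM, with a range from 100 nM to 600 nM.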

Compound 4, half-maximal inhibitory concentration: 600 nM
Compound 4: the middle estimate sits 2.4-fold (0.38 log units) below what was measured; measured number inside the range.
By their numbers in this assay, from the lowest: compound 3; then compound 1; then compound 4; then compound 2.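

Going from 4-(2-hydroxyethyl)phenyl to 4-(hydroxymethyl)phenyl brings a 2.8-fold higher number from compound 1 to compound 4 (0.44 log units; beyond the scatter) in this assay and weakens inhibition. Among the compounds shown here, this gives the first sign that the number at this position responds to chain length, even though the hydroxy group remains and the counts of hydrogen-bond donors and acceptors stay the same. No measurement shown accounts for this step.

With only these two chain lengths compared, no trend can be drawn. As far as these compounds go, it remains open whether a longer chain, such as 3-hydroxypropyl, would lower the number, or how an amine or carboxylic acid in place of the hydroxy group would behave.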